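This account rests on a few compounds, and the source may have more. Where it says the series, first, only, none or still open, it means among the compounds named here.

Compound 1 `CN(C)c1ccc(/C=N/N(Cc2ccccc2)Cc2ccccc2)cc1` gives 100000 nM in an assay on liver (Sus scrofa) for inhibition of glucose-6-phosphatase catalytic subunit 1 (Homo sapiens), using microsomes; on this read-out higher numbers stand for weaker inhibition and lower numbers for stronger inhibition.
Compound 2 `Clc1ccc(/C=N/N(Cc2ccccc2)Cc2ccccc2)cc1Cl` gives 2000 nM in this assay.

Of these two numbers, compound 2 holds the lowest and compound 1 the higher; the gap between them is beyond the usual scatter, so compound 2 is the stronger inhibitor of the pair. Compound 3 `OCc1ccc(/C=N/N(Cc2ccccc2)Cc2ccccc2)o1` has not yet been measured. It differs from compound 2 in one place: 5-(hydroxymethyl)furan-2-yl in place of 3,4-dichlorophenyl on a carbon with a double bond to nitrogen. No measured pair isolates this exact change, so the expectation rests only on the two numbers shown. Since the lower number belongs to compound 2 at 2000 nM and the change removes its 3,4-dichlorophenyl entirely, a clear step toward a higher number, beyond the scatter, is expected. The expected step is a 15-fold higher number from compound 2 to compound 3 (1.18 log units; beyond the scatter). Compound 3 is estimated to give about 30000 nM, most likely somewhere between 5000 nM and 100000 nM.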

Compound 3, half-maximal inhibitory concentration: 16000 nM
Beside the measured number, compound 3's estimate is 1.9-fold (0.27 log units) above it, and the stated range covers the measured number.
By their numbers in this assay, from the lowest: compound 2; then compound 3; then compound 1.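

Replacing 3,4-dichlorophenyl with 5-(hydroxymethyl)furan-2-yl on a carbon with a double bond to nitrogen gives, in this assay, an 8.0-fold higher number from compound 2 to compound 3 (0.90 log units; beyond the scatter), so a five-membered aromatic ring with a hetero atom still gives a finite number at this position, though a weaker one than compound 2 gives. Compound 3, at 16000 nM, sits between the two compounds with six-membered carbon rings, so having such a ring does not by itself set the number. Nothing here explains why the number rises.

This single change alters the ring and its substituents together, so it cannot show which of them drives the step. An unsubstituted furan-2-yl, or a furan carrying a carboxylic acid in place of the hydroxymethyl, would help separate the two.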